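This account rests on a few compounds, and the source may have more. Where it says the series, first, only, none or still open, it means among the compounds named here.

In an ADME assay on HELF cells (Homo sapiens) for cytotoxicity, with a stated time of 3 days (on this read-out higher numbers stand for lower toxicity in this test and lower numbers for higher toxicity in this test), compound 1 (`CC(C)[C@H](NC(=O)[C@]1(Cc2ccccc2)CCN1C(=O)OCc1ccccc1)C(N)=O`) gives 100000 nM. Compound 2 (`C[C@H](NC(=O)[C@@]1(Cc2ccccc2)CCN1C(=O)OCc1ccccc1)C(=O)N(C)C`) reads > 100000 nM, and this is a limit of the assay, not a number. Compound 3 (`CC(C)[C@H](NC(=O)[C@@]1(Cc2ccccc2)CCN1C(=O)OCc1ccccc1)C(N)=O`) has the same atoms as compound 2, joined differently: 1-carbamoyl-2-methylpropyl in place of 1-(dimethylcarbamoyl)ethyl on an amide-type nitrogen, with 1-carbamoyl-2-methylpropyl in place of 1-(dimethylcarbamoyl)ethyl on an amide-type nitrogen. Among the compounds with values here, no measured step is available as a guide, so only these two readings can inform the expectation. The expected change is no larger than the usual scatter, an at least 1.2-fold lower number from compound 2 to compound 3 (0.09 log units; that floor lies within the scatter). Compound 3 is estimated at 80000 nM, with an expected range of 30000 nM to 100000 nM.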

Compound 3, half-maximal cytotoxic concentration: 85000 nM
The estimate for compound 3 lay 1.1-fold (0.03 log units) below the measured number, and the stated range covers the measured number.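

Turning the stereocentre at a saturated ring carbon from S to R gives a 1.2-fold lower number from compound 1 to compound 3 (0.07 log units; within the scatter), so in this assay the drawn configuration at this carbon makes no difference beyond the scatter. Compound 2 reads > 100000 nM, which is a limit of the assay and not a number. Placing 1-carbamoyl-2-methylpropyl instead of 1-(dimethylcarbamoyl)ethyl on the amide-type nitrogen gives an at least 1.1-fold lower number from compound 2 to compound 3 (0.07 log units; that floor lies within the scatter), a floor and not a measured size.

Still open, as far as these compounds go, is whether an amine or a carboxylic acid in place of this group would move the number beyond the scatter. From the compounds shown here alone, the effect of inverting the other stereocentre also remains open.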